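Cyclopentyl in place of ethyl on the shared core

This account rests on a few compounds, and the source may have more. Where it says the series, first, only, none or still open, it means among the compounds named here.

Measured so far in an assay on membranes from HEK293 cells for displacement of a labelled ligand from Type-2 angiotensin II receptor (Homo sapiens), read by radioligand binding; a lower number here means a stronger inhibitor, a higher number a weaker inhibitor:
compound 1 `CCCCOC(=O)NS(=O)(=O)c1ccc(CCC)cc1-c1ccc(Cn2c(C(C)C)nc3ccccc32)cc1` gives 4 nM
compound 2 `CCCCOC(=O)NS(=O)(=O)c1ccc(CCC)cc1-c1ccc(Cn2c(CC)nc3ccccc32)cc1` gives 11 nM

Among the compounds with values here, compound 2 stands at the higher of the two numbers, and its only neighbour is compound 1. Within the data shown here, the single measured step, a 2.8-fold higher number from compound 1 to compound 2 (0.44 log units; beyond the scatter), came from hydrogen in place of methyl on a saturated chain carbon bound to an aromatic carbon and a saturated chain carbon, so the smaller group at that place gave the higher number.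

Compound 3 `CCCCOC(=O)NS(=O)(=O)c1ccc(CCC)cc1-c1ccc(Cn2c(C3CCCC3)nc3ccccc32)cc1` differs from compound 2 by cyclopentyl in place of ethyl on an aromatic carbon. Among the measured compounds shown here, only that one step bears on this change, and it points toward a lower number for the larger group, though cyclopentyl is not isopropyl and the data hold nothing on rings at this place. A modest step is therefore expected, a 2.8-fold lower number from compound 2 to compound 3 (0.44 log units; beyond the scatter), in the direction of compound 1. Compound 3 is estimated at 4 nM, with a range from 1.5 nM to 12 nM.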

Compound 3, inhibition constant: 35 nM
For compound 3 the middle estimate is 8.8-fold (0.94 log units) below the measured one; the measured number lies above the stated range.
By their numbers in this assay, from the lowest: compound 1; then compound 2; then compound 3.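

In this assay, the position on the aromatic carbon between two ring nitrogen atoms proved not to reward a larger group in a simple way: cyclopentyl in place of ethyl gave a 3.2-fold higher number from compound 2 to compound 3 (0.50 log units; beyond the scatter), the opposite direction to a 2.8-fold higher number from compound 1 to compound 2 (0.44 log units; beyond the scatter), where the methyl-bearing isopropyl gave the lower number. Cyclopentyl in place of isopropyl gave an 8.8-fold higher number from compound 1 to compound 3 (0.94 log units; beyond the scatter), so across these three compounds the number does not move steadily with the size of the group, and the only ring shown here gives the highest number. Nothing available explains this reversal.

The compounds shown leave open whether cyclopropyl or cyclobutyl would stand nearer to isopropyl than cyclopentyl does. They also leave open how an open chain such as butyl or a branched group such as tert-butyl would compare at this place.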